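A few compounds are considered here, and "the series" means these few. Any claim that something is new, unique, unknown or untested is made for them only; others in the source may bear on it.

Compound 1, `Cc1cn(C2CC(N=[N+]=[N-])C(COC(=O)OCCCCCCCCO)O2)c(=O)[nH]c1=O`: 0.0333 h in an ADME assay on the whole organism (serum) with Homo sapiens as the target; on this read-out higher numbers stand for a longer-lived compound and lower numbers for a shorter-lived compound.
Compound 2, `Cc1cn(C2CC(N=[N+]=[N-])C(COC(=O)NCCCO)O2)c(=O)[nH]c1=O`: > 48 h in this assay, a limit of the assay.
Compound 3, `Cc1cn(C2CC(N=[N+]=[N-])C(COC(=O)NCCCN)O2)c(=O)[nH]c1=O`: > 48 h in this assay, likewise a limit.

Compound 2 stands at the upper limit of this assay, not at a number, and compound 3 shares that limit, so the step that the two limits leave unreadable from compound 2 to compound 3. Against this pair stands compound 1, which carries (8-hydroxyoctyl)oxy on the carbonyl carbon and sits far lower: the step of an at least 1400-fold higher number from compound 1 to compound 2 (3.15 log units; beyond the scatter), and the step of an at least 1400-fold higher number from compound 1 to compound 3 (3.15 log units; beyond the scatter). The common feature of the two long-lived compounds is the limit of > 48 h in this assay, at which 2 of the 3 values shown sit.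

Compound 4, `Cc1cn(C2CC(N=[N+]=[N-])C(COC(=O)CCCC(=O)OC(C)(C)C)O2)c(=O)[nH]c1=O`, has not yet been measured in this assay. It differs from compound 2 as follows: 3-(tert-butoxycarbonyl)propyl in place of (3-hydroxypropyl)amino on a carbonyl carbon. The amide-type nitrogen of compound 2 leaves with this change, and what enters is, like the group of compound 1, joined to the carbonyl carbon through carbon and oxygen only. The two measured steps that bear on this both run from compound 1 to a nitrogen-linked compound and are large, so the reverse direction is expected here: a large fall in this assay, estimated as an at least 480-fold lower number from compound 2 to compound 4 (2.68 log units; beyond the scatter). Compound 4 is therefore expected to give about 0.1 h, within a range of 0.02 h to 1 h.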

Compound 4, half-life: 0.55 h
For compound 4 the middle estimate is 5.5-fold (0.74 log units) below the measured one, within the range that was stated.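

The change on this carbonyl carbon works in more than one direction in this assay: removing the amide-type nitrogen with its chain costs much of the lifetime, with an at least 87-fold lower number from compound 2 to compound 4 (1.94 log units; beyond the scatter) and an at least 87-fold lower number from compound 3 to compound 4 (1.94 log units; beyond the scatter). Yet a group joined through carbon and oxygen only does not by itself fix a compound at the short end, as 3-(tert-butoxycarbonyl)propyl in place of (8-hydroxyoctyl)oxy gives a 17-fold higher number from compound 1 to compound 4 (1.22 log units; beyond the scatter), so the two groups without nitrogen are separated from each other beyond the scatter. Among the compounds shown, only the two with an amide-type nitrogen reach the limit, and neither compound 1 nor compound 4 goes against this: the limit of > 48 h in this assay, at which 2 of the 4 values shown sit.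

Whether the nitrogen or the chain accounts for the large steps stays open, and a pair such as (8-hydroxyoctyl)amino against (8-hydroxyoctyl)oxy, or (3-hydroxypropyl)oxy against (3-hydroxypropyl)amino, would separate the two. The step between compound 2 and compound 3 cannot be read, and the free carboxylic acid in place of the tert-butyl ester of compound 4 is also left open.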